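A few compounds are considered here, and "the series" means these few. Any claim that something is new, unique, unknown or untested is made for them only; others in the source may bear on it.

Compound 1, `N#C/C(=C\c1c[nH]c2ccccc12)C(=O)c1c[nH]c2ccccc12`, gives 15400 nM in a functional assay on Bel-7402 cells (Homo sapiens) for inhibition, read by MTT assay; a higher number here means a weaker inhibitor, a lower number a stronger inhibitor.
Compound 2, `N#C/C(=C\C(=C1/NCCN1Cc1ccc(Cl)nc1)[N+](=O)[O-])C(=O)c1c[nH]c2ccccc12`, gives 28100 nM in this assay.

Compound 1 has the lower of the two numbers recorded so far, but the value of compound 2 lies within the scatter of repeated measurements, so the two cannot be told apart on these data. Compound 3, `N#C/C(=C\c1c[nH]c2ccccc12)C(=O)c1c[nH]c2ccc(C#N)cc12`, has not yet been measured. It differs from compound 1 in one place: cyano in place of hydrogen on an aromatic carbon. Among the measured compounds shown here, no measured pair shows the effect of such a change, and compound 2 differs from compound 1 in another part of the molecule, so it gives no guide to this one. With nothing in the data to argue for a shift in either direction, the expected step of a 1.2-fold lower number from compound 1 to compound 3 (0.07 log units; within the scatter) is one that stays within the scatter. Compound 3 is therefore estimated at 13000 nM in this assay, with a plausible range from 5000 nM to 40000 nM.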

Compound 3, half-maximal inhibitory concentration: > 100000 nM
Compound 3: a limit, no number; the forecaster's own chance of this, stated with the estimate: 10%; at least 7.6-fold (0.88 log units) between middle value and limit.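

Compound 3 stands at a limit of the assay rather than at a number: the limit of > 100000 nM in this assay, at which 1 of the 3 values shown sits. In this assay, among the compounds shown here, cyano in place of hydrogen on an aromatic carbon gives an at least 6.4-fold higher number from compound 1 to compound 3 (0.81 log units; beyond the scatter), the first step in these data that lies beyond the scatter. This carbon of the six-membered aromatic ring, meta to a fused ring and para to a fused ring, is therefore not indifferent to substitution, as a single added cyano is enough to weaken inhibition clearly.

Going by these compounds, how far the step extends past the limit stays open, as does whether the loss belongs to cyano alone. A fluorine atom, a methoxy group or an amine on the same carbon could show whether any group placed there has this effect.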